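Imidazolylthioalkyl ureas: branched versus straight alkyl on the imidazole

The source may report more compounds than this note shows. Statements on the series, on what has been measured and on what is new or still open speak of the compounds shown alone.

Measured so far in an assay on microsomes from liver with sterol O-acyltransferase 1 (Rattus norvegicus) as the target; a higher number here means a weaker inhibitor, a lower number a stronger inhibitor:
compound 1 `CCCCCCCN(CCCCCSc1nc(C(C)C)c(C(C)C)[nH]1)C(=O)Nc1ccc(F)cc1F` gives 20 nM
compound 2 `COCCOCCN(CCCCCSc1nc(-c2ccc(OC)cc2)c(-c2ccc(OC)cc2)[nH]1)C(=O)NC(C)C` gives 500 nM
compound 3 `CCCCCCCN(CCCCCSc1nc(-c2ccc(N(C)C)cc2)c(-c2ccc(N(C)C)cc2)[nH]1)C(=O)NC(C)C` gives 80 nM

Compound 1 has the lowest number of the three and is the strongest inhibitor among them; its nearest neighbour is compound 3, and compound 2 stands furthest away, both gaps lying beyond the scatter of this assay. Compound 1 differs from the other two in more than one place at once, so none of those gaps can be pinned to a single change.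

The next compound, compound 4 `CCCCCCCN(CCCCCSc1nc(CCC)c(CCC)[nH]1)C(=O)Nc1ccc(F)cc1F`, keeps the heptyl chain, the difluorophenyl urea and the five-carbon linker of compound 1 and alters only the imidazole substituents: 4,5-dipropyl-1H-imidazol-2-yl in place of 4,5-diisopropyl-1H-imidazol-2-yl on a sulfur. Same atom count, same ring, same donor and acceptor count; only the branching of the two alkyl groups on the imidazole changes.

Going by the values given here, no measured pair isolates this kind of change, so the expectation rests on compound 1 alone. A modest step, expected to be a 1.8-fold higher number from compound 1 to compound 4 (0.24 log units; within the scatter), towards a somewhat higher number seems the likeliest outcome, with no change beyond the scatter also quite possible. Compound 4 is therefore estimated at 35 nM in this assay, within a range of 12 nM to 110 nM.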

Compound 4, half-maximal inhibitory concentration: 60 nM
For compound 4 the middle estimate is 1.7-fold (0.23 log units) below the measured one; the range from low to high includes it.
By their numbers in this assay, from the lowest: compound 1; then compounds 4 and 3 (each within the scatter of the next); then compound 2.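

In this assay, going by these compounds alone, the change to 4,5-dipropyl-1H-imidazol-2-yl in place of 4,5-diisopropyl-1H-imidazol-2-yl on a sulfur gives a 3.0-fold higher number from compound 1 to compound 4 (0.48 log units; beyond the scatter) and is the first step that can be tied to a single place. The atoms, the ring and the donor and acceptor counts stay the same, so the branching of the two alkyl groups on the imidazole is enough on its own to move the number beyond the scatter, with the diisopropyl compound 1 holding the lower number of this pair. Nothing measured on this pair accounts for the step.

The compounds shown leave open how other groups on a sulfur-bound imidazole would fall relative to this pair, for instance 4,5-diethyl, 4,5-di-tert-butyl or 4,5-dicyclohexyl substituents. Also open, from the compounds shown here alone, is whether the same change from branched to straight alkyl gives a step of similar size once the heptyl chain or the difluorophenyl urea shared by compound 1 and compound 4 is replaced, for example by a benzyl group or an isopropyl urea.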